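The compounds below may be only part of what the source reports. "The series", "measured", "known", "first", "only" and "open" are said of these compounds alone.

In a functional assay on MGC-803 cells (Homo sapiens) for cytotoxicity, read by MTT assay, with stated times of 48 h and 4 h (on this read-out higher numbers stand for weaker inhibition and lower numbers for stronger inhibition), three compounds on one shared core differ only in the amine at the end of the chain. For compound 1 `CCN(CC)CCNc1nc(/C=C/c2ccc(OC)c(OC)c2)nc2ccccc12` the assay gives only a limit, > 100000 nM. Compound 2 `COc1ccc(/C=C/c2nc(NCCN(C(C)C)C(C)C)c3ccccc3n2)cc1OC` gives 15500 nM, and compound 3 `COc1ccc(/C=C/c2nc(NCCN3CCCCC3)c3ccccc3n2)cc1OC` gives 33200 nM. Compound 3 thus holds the higher of the two actual numbers, with the gap between them being a 2.1-fold higher number from compound 2 to compound 3 (0.33 log units; beyond the scatter). Against the limit, the other amine exchanges give an at least 6.4-fold lower number from compound 1 to compound 2 (0.80 log units; beyond the scatter) and an at least 3.0-fold lower number from compound 1 to compound 3 (0.47 log units; beyond the scatter).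

Compound 4 `COc1ccc(/C=C/c2nc(NCCN3CCCCC3)c3cc(Cl)ccc3n2)cc1OC` keeps the amine of compound 3 and changes the core instead: chloro in place of hydrogen on an aromatic carbon. For the measured compounds named here, no measured step touches that carbon, so the amine steps serve only as a rough gauge of size, chiefly a 2.1-fold higher number from compound 2 to compound 3 (0.33 log units; beyond the scatter). A modest move toward a lower number is expected, but the direction remains uncertain. The expected step is a 2.2-fold lower number from compound 3 to compound 4 (0.35 log units; beyond the scatter). For compound 4 the estimate is 15000 nM, with an expected range from 5000 nM to 60000 nM.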

Compound 4, half-maximal inhibitory concentration: 13500 nM
Beside the measured number, compound 4's estimate is 1.1-fold (0.05 log units) above it, within the range that was stated.
By their numbers in this assay, from the lowest: compounds 4 and 2 (each within the scatter of the next); then compound 3. At a limit, above all of these: compound 1.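

In this assay, chloro in place of hydrogen on an aromatic carbon, meta to a fused ring and para to a fused ring, gives a 2.5-fold lower number from compound 3 to compound 4 (0.39 log units; beyond the scatter). For the compounds shown here, all earlier steps changed only the amine, so this is the first sign that the shared core itself can shift the number beyond the scatter, and a single heavy atom at this carbon is enough to do so. Nothing measured here gives a reason for this step.

As far as these compounds go, whether fluoro, bromo, methoxy or a nitrile on this carbon would move the number in the same direction remains open. From the compounds shown here alone, it is also open whether chloro would produce a similar step when paired with the diisopropylamino or diethylamino group in place of piperidin-1-yl.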